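Compound 3 to compound 4: methoxy to hydroxy near the limit

The source may hold more compounds than are shown below. What is called first, only, known or untested is meant among the compounds shown, and "the series" means these compounds.

In a functional assay on A549 cells (Homo sapiens) for inhibition, read by MTT assay, with a stated time of 72 h (on this read-out higher numbers stand for weaker inhibition and lower numbers for stronger inhibition), compound 1 `COc1cc(/C=C/C(=O)c2c(OC)cc(O)c(CC=C(C)C)c2O)ccc1O` gives 11800 nM, and compound 2 `COc1cc(O)c(CC=C(C)C)c(O)c1C(=O)/C=C/c1ccc(O)c(O)c1` gives 16100 nM. Compound 3 `COc1cc(/C=C/C(=O)c2c(O)cc(O)cc2OC)ccc1O` gives > 50000 nM, which is a limit and not a number. Its position rests on an at least 4.2-fold higher number from compound 1 to compound 3 (0.62 log units; beyond the scatter), the step that puts hydrogen in place of 3-methylbut-2-en-1-yl on an aromatic carbon.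

Compound 4 `COc1cc(O)cc(O)c1C(=O)/C=C/c1ccc(O)c(O)c1` differs from compound 3 by hydrogen in place of methyl on an oxygen on an aromatic ring, or methoxy to hydroxy. The same change has been measured once, as a 1.4-fold higher number from compound 1 to compound 2 (0.13 log units; within the scatter), and that step lies within the scatter. That pair carries the 3-methylbut-2-en-1-yl group, which compound 3 lacks, so the read-across rests on a single pair. No step beyond the scatter is therefore expected in this assay, and a further report as a limit is likely. The expected change is a step that the limit leaves unreadable from compound 3 to compound 4. For compound 4 the estimated value is 60000 nM, with an expected range of 30000 nM to 120000 nM.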

Compound 4, half-maximal inhibitory concentration: 11800 nM
Compound 4: middle estimate off by 5.1-fold (0.71 log units), on the high side; the whole stated range lies above it.
By their numbers in this assay, from the lowest: compounds 1, 4 and 2 (each within the scatter of the next). At a limit, above all of these: compound 3.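

In this assay, hydrogen in place of methyl on an oxygen on an aromatic ring gives an at least 4.2-fold lower number from compound 3 to compound 4 (0.62 log units; beyond the scatter) when the 3-methylbut-2-en-1-yl group is absent, so the size of this change depends on the core: the same change on two cores in this assay, a 1.4-fold higher number (0.13 log units; within the scatter) from compound 1 to compound 2 and an at least 4.2-fold lower number (0.62 log units; beyond the scatter) from compound 3 to compound 4, at least 5.7-fold (0.76 log units) apart, beyond the scatter of two such steps

With the hydroxy group in place, hydrogen in place of 3-methylbut-2-en-1-yl on an aromatic carbon gives a 1.4-fold lower number from compound 2 to compound 4 (0.13 log units; within the scatter), so that change also depends on the core: the same change on two cores in this assay, an at least 4.2-fold higher number (0.62 log units; beyond the scatter) from compound 1 to compound 3 and a 1.4-fold lower number (0.13 log units; within the scatter) from compound 2 to compound 4, at least 5.7-fold (0.76 log units) apart, beyond the scatter of two such steps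

Compound 3 gives > 50000 nM, which is a limit and not a number.

The compounds shown leave open whether this dependence on the core holds for an ethoxy group in place of methoxy, or for a longer chain in place of 3-methylbut-2-en-1-yl. They also do not tell which feature of either group underlies it.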